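The source may report more compounds than this note shows. Statements on the series, on what has been measured and on what is new or still open speak of the compounds shown alone.

The shared core appears in compound 1 `CC[C@H](C)[C@H](NC(=O)c1cnc2ccccc2c1Cl)C(=O)OC`, which in an ADME assay on CCRF-CEM cells (Homo sapiens) for cytotoxicity (a lower number here means that less compound is tolerated, a higher number that more compound is tolerated), gives 23.3 uM. Compound 2 `COC(=O)[C@H](CO)NC(=O)c1cnc2ccccc2c1Cl` differs from it by a hydroxymethyl in place of sec-butyl on the saturated chain carbon bound to the amide-type nitrogen and the carbonyl carbon. For compound 2 the result in this assay is a limit of the assay, > 100 uM, so only a range is known for where compound 2 stands. Going by the values given here, the single measured step, an at least 4.2-fold higher number from compound 1 to compound 2 (0.63 log units; beyond the scatter), runs into that limit, as the limit of > 100 uM in this assay, at which 1 of the 2 values shown sits, shows. Compound 3 `COC(=O)[C@H](CO)NC(=O)c1cnc2c(C)cccc2c1Cl` carries methyl in place of hydrogen on an aromatic carbon. Among the compounds with values here, no measured step touches an aromatic carbon, so the one step recorded gives no guide to this change, and for compound 3 the shift in half-maximal toxic concentration is expected to stay within the scatter, an at least 1.1-fold lower number from compound 2 to compound 3 (0.04 log units; that floor lies within the scatter). Compound 3 is therefore estimated at 90 uM, in a range from 30 uM to 300 uM.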

Compound 3, half-maximal toxic concentration: > 100 uM
Compound 3 gave a limit, no number (the forecaster's own chance of this, stated with the estimate: 55%); at least 1.1-fold (0.04 log units) between middle value and limit.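

Compound 2 and compound 3 both end at a limit of this assay, so no step can be read between them: the limit of > 100 uM in this assay, at which 2 of the 3 values shown sit.

On these data alone, whether methyl in place of hydrogen on an aromatic carbon shifts the half-maximal toxic concentration at all, and in which direction, remains open.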